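The source may report more compounds than this note shows. Statements on the series, on what has been measured and on what is new or still open speak of the compounds shown alone.

Measured in an ADME assay (liver) for metabolic stability, with Liver microsome (Rattus norvegicus) as the target, read by LC-MS, using microsomes and NADPH, with stated times of 5 min and 60 min, tested at 4 uM; a higher number here means that more of the compound is left, a lower number that less of the compound is left:

- Compound 1 (`Cc1c(OCCCCOc2cccc(C(=O)O)c2)ccc(C(=O)CC2CCCC2)c1O`): 55%
- Compound 2 (`COc1ccc(C(=O)O)cc1OCCCCOc1ccc(C(=O)CC2CCCC2)c(O)c1C`): 14%
- Compound 3 (`Cc1ccc(C(=O)O)cc1OCCCCOc1ccc(C(=O)CC(C)C)c(O)c1C`): 21%

In this assay, compound 3 at 21% lies within the scatter of compound 2 at 14%, and both values lie well under that of compound 1. Compound 4 (`Cc1ccc(C(=O)O)cc1OCCCCOc1ccc(C(=O)CC2CCCC2)c(O)c1C`) differs from compound 3 by cyclopentyl in place of isopropyl on a saturated chain carbon bound to a carbonyl carbon, with cyclopentyl in place of isopropyl on a saturated chain carbon bound to a carbonyl carbon. Among the compounds with values here, the only measured step, a number 41 percentage points lower from compound 1 to compound 2 (beyond the scatter), is large, but it is a different change, methoxy in place of hydrogen on an aromatic carbon, so no measured step speaks directly to this one. Compound 2 already carries cyclopentyl and gives 14%, so no shift beyond the scatter is expected. The expected step is a number 3 percentage points lower from compound 3 to compound 4 (within the scatter). For compound 4 the estimated value is 18%, with an expected range of 7% to 35%.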

Compound 4, percent of the compound remaining: 9%
Beside the measured number, compound 4's estimate is 9 percentage points above it; the range from low to high includes it.
By their numbers in this assay, from the lowest: compounds 4, 2 and 3 (each within the scatter of the next, the first and the last beyond it); then compound 1.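

Cyclopentyl in place of isopropyl on a saturated chain carbon bound to a carbonyl carbon gives a number 12 percentage points lower from compound 3 to compound 4 (beyond the scatter) in this assay, so a change at this position does register in the read-out. Methyl in place of hydrogen on an aromatic carbon gives a number 46 percentage points lower from compound 1 to compound 4 (beyond the scatter), whereas methyl in place of methoxy gives a number 5 percentage points lower from compound 2 to compound 4 (within the scatter), so methyl and methoxy do not separate there. Nothing available explains these steps. Left open is how a cyclohexyl group or a longer chain would read at the saturated chain carbon, and how fluorine would read on the aromatic carbon.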